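Adding trifluoromethyl to the benzyl group of compound 2

This account rests on a few compounds, and the source may have more. Where it says the series, first, only, none or still open, it means among the compounds named here.

Of the compounds shown here, three share one core and have been tested in a functional assay on HeLa cells (Homo sapiens) for cytotoxicity, read by MTT assay, with a stated time of 72 h; a higher number here means a weaker inhibitor, a lower number a stronger inhibitor. Compound 2, `Cc1cc(S(=O)(=O)/N=C(\N)n2nccc2-c2ccccc2)c(SCc2ccccc2)cc1Cl`, gives 5000 nM. Compound 3, `Cc1cc(-c2ccccc2)n(/C(N)=N/S(=O)(=O)c2cc(C)c(Cl)cc2SCc2ccccc2)n1`, gives 5000 nM, and compound 1, `Cc1cc(-c2ccccc2)n(/C(N)=N/S(=O)(=O)c2cc(C)c(Cl)cc2SCc2cccc(C(F)(F)F)c2)n1`, gives 98000 nM. Compound 2 therefore stands level with compound 3 at the digits shown, the two lowest numbers of the three, while compound 1 sits far above them.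

Compound 4, `Cc1cc(S(=O)(=O)/N=C(\N)n2nccc2-c2ccccc2)c(SCc2cccc(C(F)(F)F)c2)cc1Cl`, differs from compound 2 by trifluoromethyl in place of hydrogen on an aromatic carbon. This is the reverse of the change between compound 1 and compound 3, where a 20-fold lower number from compound 1 to compound 3 (1.29 log units; beyond the scatter). The other difference, no change at the digits printed from compound 2 to compound 3 (within the scatter), shows that the two pairs are closely comparable. The step from compound 2 to compound 4 is therefore expected to be a large rise in the number, much like the reverse of the step from compound 1 to compound 3, so that a 16-fold higher number from compound 2 to compound 4 (1.20 log units; beyond the scatter). Compound 4 is estimated to give 80000 nM in this assay , within a range from 20000 nM to 300000 nM.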

Compound 4, half-maximal inhibitory concentration: 19000 nM
The estimate for compound 4 lay 4.2-fold (0.62 log units) above the measured number, and the stated range ends above it.
By their numbers in this assay, from the lowest: compounds 2 and 3 (each within the scatter of the next); then compound 4; then compound 1.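

In this assay, trifluoromethyl on the benzyl group still raises the number when the ring methyl is absent, a 3.8-fold higher number from compound 2 to compound 4 (0.58 log units; beyond the scatter), but the size of this step depends on the core that carries it: the same change on two cores in this assay, a 20-fold lower number (1.29 log units; beyond the scatter) from compound 1 to compound 3 and a 3.8-fold lower number (0.58 log units; beyond the scatter) from compound 4 to compound 2, 5.2-fold (0.71 log units) apart, beyond the scatter of two such steps

The ring methyl that made no difference with a plain benzyl group does make a difference once trifluoromethyl is present, a 5.2-fold lower number from compound 1 to compound 4 (0.71 log units; beyond the scatter), so its step also depends on the rest of the molecule: the same change on two cores in this assay, no change at the digits printed (within the scatter) from compound 2 to compound 3 and a 5.2-fold higher number (0.71 log units; beyond the scatter) from compound 4 to compound 1, 5.2-fold (0.71 log units) apart, beyond the scatter of two such steps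

Across these four compounds, then, the two changes do not act independently of each other.

The compounds shown leave open how a methoxy group, an amine or a carboxylic acid in place of that trifluoromethyl would behave on either core. They also do not tell why the two changes depend on each other.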